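The compounds below may be only part of what the source reports. "The series", "measured", "known", "first", "only" and "open" are said of these compounds alone.

Measured compounds:
Compound 1 `CC1(C)Oc2ccc(C#N)cc2[C@@H](/N=C(\NC#N)Nc2ccc(Cl)cc2)[C@@H]1O` — 1800 nM
Compound 2 `CC1(C)Oc2ccc(C(=O)c3ccccc3)cc2[C@@H](/N=C(\NC#N)Nc2ccc(Cl)cc2)[C@@H]1O` — 7100 nM
Compound 3 `CC1(C)Oc2ccc(Cc3ccccc3)cc2[C@@H](/N=C(\NC#N)Nc2ccc(Cl)cc2)[C@@H]1O` — 10000 nM

In a functional assay (aorta) with Rattus norvegicus as the target (a lower number here means a stronger inhibitor, a higher number a weaker inhibitor), compound 2 stands second highest of the three numbers: compound 1 sits lower, by a 3.9-fold higher number from compound 1 to compound 2 (0.60 log units; beyond the scatter), while compound 3 sits within the scatter, by a 1.4-fold higher number from compound 2 to compound 3 (0.15 log units; within the scatter). Compound 4 `CC(C)(C)C(=O)c1ccc2c(c1)[C@@H](/N=C(\NC#N)Nc1ccc(Cl)cc1)[C@H](O)C(C)(C)O2` differs from compound 2 by tert-butyl in place of phenyl on a carbonyl carbon. Among the measured compounds shown here, no measured step swaps phenyl for tert-butyl, so the bearing steps are indirect: replacing cyano by benzoyl gave a modest rise, and exchanging benzoyl for benzyl gave none beyond the scatter. A change confined to the group on the carbonyl carbon is therefore expected to move the number little, with a 1.0-fold lower number from compound 2 to compound 4 (0.01 log units; within the scatter). Compound 4 is estimated at 7000 nM, within a range from 2500 nM to 20000 nM.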

Compound 4, half-maximal inhibitory concentration: 5400 nM
Beside the measured number, compound 4's estimate is 1.3-fold (0.11 log units) above it; measured number inside the range.
By their numbers in this assay, from the lowest: compound 1; then compounds 4, 2 and 3 (each within the scatter of the next).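

In this assay, putting tert-butyl in place of phenyl on the carbonyl carbon removes the aromatic ring yet stays within the scatter, with a 1.3-fold lower number from compound 2 to compound 4 (0.12 log units; within the scatter), and a 1.9-fold lower number from compound 3 to compound 4 (0.27 log units; within the scatter) also stays within it. The gap to the nitrile remains beyond the scatter, with a 3.0-fold higher number from compound 1 to compound 4 (0.48 log units; beyond the scatter), so an aromatic ring on the carbonyl is not required for that gap to appear. Nothing available explains these steps. Going by these compounds, whether an amine or a carboxylic acid on this aromatic carbon would fall nearer compound 1 or compound 4 stays open, as does the effect of a longer chain on the carbonyl carbon.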